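Replacing Morpholine with Phenylurea on the Sulfonyl Sulfur

A few compounds are considered here, and "the series" means these few. Any claim that something is new, unique, unknown or untested is made for them only; others in the source may bear on it.

Of the compounds shown here, three built on one shared core have been tested in a functional assay on the whole organism (aorta) with Rattus norvegicus as the target; on this read-out higher numbers stand for larger maximal responses and lower numbers for smaller maximal responses. Compound 1 `CC1(C)C=C(n2ccccc2=O)c2cc(S(N)(=O)=O)ccc2O1` reaches 77.5%. Compound 2 `CN(C)S(=O)(=O)c1ccc2c(c1)C(n1ccccc1=O)=CC(C)(C)O2`, with dimethylamino in place of amino on the sulfonyl sulfur, reaches 78.3%. Compound 3 `CC1(C)C=C(n2ccccc2=O)c2cc(S(=O)(=O)N3CCOCC3)ccc2O1`, with morpholin-4-yl on that sulfur, reaches 75.5%. Compound 3 sits at the lower edge of the three numbers, yet the gaps are small: a number 2 percentage points lower from compound 1 to compound 3 (within the scatter) and a number 2.8 percentage points lower from compound 2 to compound 3 (within the scatter), and between the other two a number 0.8 percentage points higher from compound 1 to compound 2 (within the scatter).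

Compound 4 `CC1(C)C=C(n2ccccc2=O)c2cc(S(=O)(=O)NC(=O)Nc3ccccc3)ccc2O1` has not yet been measured. Its change from compound 3 is (phenylcarbamoyl)amino in place of morpholin-4-yl on a sulfonyl sulfur. Within the data shown here, the steps that bear on it are the two that end at compound 3 and the one between compound 1 and compound 2, all of which stayed within the scatter even though the group on the sulfonyl sulfur changed each time. The entering group is larger than any tried so far, so the expectation carries some uncertainty, but no step beyond the scatter is expected. The expected step is a number 0.5 percentage points higher from compound 3 to compound 4 (within the scatter). Compound 4 is therefore estimated at 76%, with a range from 64% to 86%.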

Compound 4, largest response reached (Emax), in percent of the reference or control that the assay uses: 90.8%
Estimate against measurement, compound 4: 14.8 percentage points below, and the stated range ends below it.
By their numbers in this assay, from the lowest: compounds 3, 1 and 2 (each within the scatter of the next); then compound 4.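

Changing the group on the sulfonyl sulfur can shift the maximal response in this assay beyond the scatter: with (phenylcarbamoyl)amino on that sulfur, the data show a number 15.3 percentage points higher from compound 3 to compound 4 (beyond the scatter) and a number 12.5 percentage points higher from compound 2 to compound 4 (beyond the scatter) as well. Read as an addition to the sulfonamide of compound 1, phenylcarbamoyl in place of hydrogen on the nitrogen gives a number 13.3 percentage points higher from compound 1 to compound 4 (beyond the scatter) in the same assay. Amino, dimethylamino and morpholin-4-yl stayed within the scatter of one another, so this position tolerates those three alike but responds to the larger group, which also brings an aromatic ring, a carbonyl and hydrogen-bond donors.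

The data available here give no explanation for the rise. Which part of the entering group matters stays open, and a methylcarbamoyl group or a benzoyl group on the sulfonamide nitrogen would help to separate the phenyl ring from the rest.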